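The source may hold more compounds than are shown below. What is called first, only, known or untested is meant among the compounds shown, and "the series" means these compounds.

Measured compounds:
- compound 1 `ClCc1ccccc1Cn1cnc2c(Cl)nc(Cl)nc21`: 130 nM
- compound 2 `ClCc1cccc(Cn2cnc3c(Cl)ncnc32)c1`: 11200 nM

In a functional assay on DU-145 cells (Homo sapiens) for cytotoxicity, read by sulforhodamine B assay, with a stated time of 48 h (on this read-out lower numbers stand for stronger inhibition of growth and higher numbers for weaker inhibition of growth), compound 1 gives 130 nM, the lowest of the two numbers in hand. Compound 2, which carries its chloromethyl group at a different position of the benzyl ring and lacks one chloro on the core, gives 11200 nM in this assay; the two values lie far apart, beyond the scatter, but the two structures differ in more than one place, so the gap cannot be assigned to either change alone.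

Compound 3 `Nc1nc(Cl)c2ncn(Cc3ccccc3CCl)c2n1` is not yet measured. It differs from compound 1 in one place: amino in place of chloro on an aromatic carbon. The amino enters on an aromatic carbon of a six-membered aromatic ring with 2 nitrogen, between two ring nitrogen atoms, meta to a chloro group. For the measured compounds named here, no measured pair isolates this change, so its size is open. The working expectation is a modest loss in this assay, with the step from compound 1 to compound 3 estimated at a 3.1-fold higher number from compound 1 to compound 3 (0.49 log units; beyond the scatter). Compound 3 is accordingly expected near 400 nM, within 100 nM to 2000 nM.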

Compound 3, concentration for 50% growth inhibition: 14800 nM
Compound 3: the middle estimate sits 37-fold (1.57 log units) below what was measured, outside the stated range (above it).
By their numbers in this assay, from the lowest: compound 1; then compounds 2 and 3 (each within the scatter of the next).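

In this assay, the step from compound 1 to compound 3 gives the series its first reading of a single change: amino in place of chloro on an aromatic carbon, between two ring nitrogen atoms, produces a 110-fold higher number from compound 1 to compound 3 (2.06 log units; beyond the scatter). This position on the core is therefore far from indifferent to its substituent, with the chloro of compound 1 giving much stronger growth inhibition than the amino of compound 3 while the chloromethyl-bearing benzyl group stays the same. Nothing available bears on why this single replacement carries so large a step, so the result stands as an observation about this pair alone.

The compounds shown do not tell whether the step is specific to amino or would follow any replacement of the chloro at this carbon; a methyl, a methoxy or a dimethylamino group there would help separate those two readings. On these data alone, it also stays open whether the same replacement would have a step of similar size with the chloromethyl group at another position of the benzyl ring, or with a fluoro or bromo in place of the other chloro on the core.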